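Working notes: chloro in place of methyl in compound 1

A few compounds are considered here, and "the series" means these few. Any claim that something is new, unique, unknown or untested is made for them only; others in the source may bear on it.

Measured in a functional assay on A549 cells (Homo sapiens) for inhibition, read by MTT assay, with a stated time of 48 h; on this read-out lower numbers stand for stronger inhibition and higher numbers for weaker inhibition:
- compound 1 (`Cc1nc(N(C)c2ccc([Se]C#N)c(C)c2)c2ccccc2n1`) gives 8 nM
- compound 2 (`COc1ccc(N(C)c2nc(C)nc3ccccc23)cc1[Se]C`) gives 11 nM
- compound 3 (`COc1ccc(N(C)c2nc(C)nc3ccccc23)cc1C(=O)OCCCC[Se]C#N`) gives 155 nM

Compound 1 and compound 2 lie within the scatter of each other, and compound 3 lies beyond the scatter from both at the high end of the three numbers. The next compound to be read is compound 4 (`Cc1nc(N(C)c2ccc([Se]C#N)c(Cl)c2)c2ccccc2n1`), which differs from compound 1 as follows: chloro in place of methyl on an aromatic carbon. In words, chloro replaces methyl on an aromatic carbon. Within the data shown here, the only measured single-place step, a 14-fold higher number from compound 2 to compound 3 (1.15 log units; beyond the scatter), exchanges a far larger group than this one-atom swap, so it gives no size for the swap. Among the measured compounds shown here, no measured pair tests chloro against methyl. With nothing pointing either way, the expectation in this assay is no change beyond the scatter, and the expected step is a 1.3-fold higher number from compound 1 to compound 4 (0.10 log units; within the scatter). For compound 4 the estimated value is 10 nM, with an expected range from 3 nM to 30 nM.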

Compound 4, half-maximal inhibitory concentration: 7 nM
Compound 4: middle estimate off by 1.4-fold (0.15 log units), on the high side; the range from low to high includes it.
By their numbers in this assay, from the lowest: compounds 4, 1 and 2 (each within the scatter of the next); then compound 3.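

In this assay, chloro in place of methyl on an aromatic carbon gives a 1.1-fold lower number from compound 1 to compound 4 (0.06 log units; within the scatter), so at this position the two groups cannot be told apart in this read-out. Among these compounds, this is the first measured pair to test this position, as the earlier step exchanged a far larger group in another place and gave no reading for a one-atom swap. Nothing available explains why the two groups read alike.

As far as these compounds go, whether the position keeps these low numbers with a different kind of group, such as an amine, a carboxylic acid or a longer chain, remains open. Also open, from the compounds shown here alone, is whether chloro and methyl still read alike when the group ortho to them is exchanged for another group.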